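A Thiophene Replaces Methoxyphenyl on a Shared Core

The source may hold more compounds than are shown below. What is called first, only, known or untested is meant among the compounds shown, and "the series" means these compounds.

Compound 1 (`COc1ccc(-c2cccc3c(Cl)c(Br)c(C(F)(F)F)nc23)cc1`) was tested in an assay for inhibition of ectonucleoside triphosphate diphosphohydrolase 2 (Homo sapiens), read by malachite green, with a stated time of 10 min; a higher number here means a weaker inhibitor, a lower number a stronger inhibitor. In this assay compound 1 gives > 300000 nM, which is a limit of the assay and not a number. Compound 2 (`FC(F)(F)c1ccc(-c2cccc3c(Cl)c(Br)c(C(F)(F)F)nc23)cc1`) differs from compound 1 only by trifluoromethyl in place of methoxy on an aromatic carbon. In this assay compound 2 gives > 300000 nM, again a limit of the assay rather than a number. The step that the two limits leave unreadable from compound 1 to compound 2 therefore cannot be read in size or direction. What the two values share is the limit of > 300000 nM in this assay, at which 2 of the 2 values shown sit.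

Compound 3 (`FC(F)(F)c1nc2c(-c3ccsc3)cccc2c(Cl)c1Br`) has not yet been measured. Its difference from compound 1 is thiophen-3-yl in place of 4-methoxyphenyl on an aromatic carbon. Among the measured compounds shown here, the only measured step, from compound 1 to compound 2, bears on this change just in that both of its ends sit at the limit, so it gives no readable size to carry over. Compound 3 is therefore expected to stay near the same limit, with the step of a number no higher from compound 1 to compound 3 (the limit leaves the size open) expected to be small. Compound 3 is estimated at 300000 nM, with a range from 80000 nM to 1000000 nM.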

Compound 3, half-maximal inhibitory concentration: > 300000 nM
Compound 3: no number, only a limit (the forecaster's own chance of this, stated with the estimate: 80%); the middle value sits exactly at the limit.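

In this assay compound 3 gives > 300000 nM, which is a limit of the assay and not a number, so the step between compound 1 and compound 3 cannot be read. All three compounds share one result: the limit of > 300000 nM in this assay, at which 3 of the 3 values shown sit.

The compounds shown leave open which change to the shared core, if any, would give a readable number.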